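The source may report more compounds than this note shows. Statements on the series, on what has been measured and on what is new or still open speak of the compounds shown alone.

Compound 1 `Cc1ncc2cnnc(S)n12` gives > 48000 nM, which is a limit of the assay and not a number.
Compound 2 `C=CCSc1nncc2cnc(-c3ccccc3)n12` gives > 48000 nM, again a limit of the assay.
Compound 3 `Oc1nncc2cnc(-c3ccccc3)n12` gives > 48000 nM, also a limit of the assay.

The read-out throughout is a functional assay for inhibition, with Homo sapiens as the target; on this read-out higher numbers stand for weaker inhibition and lower numbers for stronger inhibition. Compound 2 therefore stands at the assay limit, and so do the other two measured compounds: all three sit at the limit of > 48000 nM in this assay, at which 3 of the 3 values shown sit. For the measured compounds named here, the one measured step that touches compound 2, a step that the two limits leave unreadable from compound 2 to compound 3, is for that reason unreadable in size.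

Compound 4 `C=CCSc1nncc2cnc(C)n12` differs from compound 2 by methyl in place of phenyl on an aromatic carbon. Compound 1 also carries a methyl group on its shared core and likewise gives only a limit in this assay. Going by the values given here, no measured step shows any change of this kind bringing inhibition into the measurable range, so compound 4 is expected to stay at the limit as well, and the expected step that the limit leaves unreadable from compound 2 to compound 4 is none beyond the scatter. Compound 4 is thus estimated at 80000 nM, with a range from 30000 nM to 300000 nM, most likely reported only as a limit.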

Compound 4, half-maximal inhibitory concentration: 61000 nM
Compound 4: middle estimate off by 1.3-fold (0.12 log units), on the high side, within the range that was stated.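

The steps from compound 2 to compound 4 and from compound 1 to compound 4 cannot be read, because compound 2 and compound 1 give only a limit: the limit of > 48000 nM in this assay, at which 3 of the 4 values shown sit.

The compounds shown leave open how much swapping phenyl for methyl, or adding allyl on the sulfur, changes inhibition in this assay.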